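The source may hold more compounds than are shown below. What is called first, only, known or untested is meant among the compounds shown, and "the series" means these compounds.

In a functional assay on MCF7 cells (Homo sapiens) for inhibition, read by MTT assay, with a stated time of 3 days (a higher number here means a weaker inhibitor, a lower number a stronger inhibitor), compound 1 `COc1cc(-c2nc3ccccc3s2)ccc1OCC(=O)NNC(=O)CCl` gives 780 nM, while compound 2 `CCOC(=O)[C@H](CS)NCC(=O)NNC(=O)COc1ccc(-c2nc3ccccc3s2)cc1OC` gives 2880 nM. Compound 2 therefore has the higher of the two numbers and is the weaker inhibitor of this pair. For the measured compounds named here, the only measured step between them is a 3.7-fold higher number from compound 1 to compound 2 (0.57 log units; beyond the scatter), and it came from placing (1-(ethoxycarbonyl)-2-sulfanylethyl)amino where chloro had been.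

Compound 3 `CCOC(=O)[C@H](CS(=O)(=O)O)NCC(=O)NNC(=O)COc1ccc(-c2nc3ccccc3s2)cc1OC` differs from compound 2 in one group: sulfo in place of sulfanyl on a saturated chain carbon, two bonds along the chain from an amine nitrogen and a carbonyl carbon. In words, this is sulfo in place of sulfanyl on a saturated chain carbon, two bonds along the chain from an amine nitrogen and a carbonyl carbon. Going by the values given here, no measured pair shows this exact swap, so the evidence is thin. The step from compound 1 gives only a rough guide to size, since it introduced the sulfanyl-bearing group rather than altering it.

With little certainty about direction, the expected modest move in this assay is a 2.1-fold higher number from compound 2 to compound 3 (0.32 log units; beyond the scatter). For compound 3, the estimated value is 6000 nM, with an expected range of 1500 nM to 25000 nM.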

Compound 3, half-maximal inhibitory concentration: 1990 nM
Beside the measured number, compound 3's estimate is 3.0-fold (0.48 log units) above it; measured number inside the range.
By their numbers in this assay, from the lowest: compound 1; then compounds 3 and 2 (each within the scatter of the next).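

In this assay, the change from sulfanyl to sulfo on this saturated chain carbon gives a 1.4-fold lower number from compound 2 to compound 3 (0.16 log units; within the scatter), which lies within the scatter, so this assay does not separate the two groups, even though sulfo brings 3 oxygen atoms that sulfanyl lacks. The chloro compound stays apart from the sulfo compound, with a 2.6-fold higher number from compound 1 to compound 3 (0.41 log units; beyond the scatter), which is beyond the scatter; compounds 2 and 3 therefore both show higher numbers than compound 1, whichever of the two groups ends the side chain. No available evidence bears on what lies behind these numbers.

The compounds shown leave open whether the same flat result would hold for other groups on this chain carbon, such as a hydroxyl, a carboxylic acid or an amine, or for a longer chain carrying the sulfo group. They also leave open which part of the (1-(ethoxycarbonyl)-2-sulfoethyl)amino group goes with the step away from chloro, since a simple amino group or an ethyl ester alone would be needed to divide that step into its parts.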